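The compounds below may be only part of what the source reports. "The series", "measured", "known", "first", "only" and "open" are said of these compounds alone.

Measured so far:
compound 1 `CCN1C(=O)S/C(=C\c2ccc(N)cc2)C1=O` — in a functional assay on FM3A cells (Mus musculus) for cytotoxicity, read by cell counting, with a stated time of 2 days (a lower number here means a stronger inhibitor, a higher number a weaker inhibitor), compound 1 gives 76000 nM
compound 2 `C=C(Br)C(=O)Nc1ccc(/C=C2\SC(=O)N(Cc3ccc(Cl)cc3)C2=O)cc1` — in this assay compound 2 gives 5100 nM
compound 3 `Nc1ccc(/C=C2\SC(=O)N(Cc3ccc(Cl)cc3)C2=O)cc1` — in this assay compound 3 gives 60000 nM

Compound 2 holds the lowest number of the three. Its nearest neighbour is compound 3, reached by a 12-fold higher number from compound 2 to compound 3 (1.07 log units; beyond the scatter); compound 1 lies further off still. The remaining step, a 1.3-fold lower number from compound 1 to compound 3 (0.10 log units; within the scatter), changes the group on the saturated chain carbon bound to the amide-type nitrogen in the ring and stays within the scatter.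

Compound 4 `C=C(Br)C(=O)Nc1ccc(/C=C2\SC(=O)N(Cc3cccc(Cl)c3)C2=O)cc1` is not yet measured. It differs from compound 2 only by 3-chlorophenyl in place of 4-chlorophenyl on a saturated chain carbon bound to an amide-type nitrogen in a ring; the two share every atom and differ in how they are joined.

For the measured compounds named here, no measured pair moves the chlorine around the benzyl ring, so nothing bears directly on this change. Going by the values given here, the one step at the same place, a 1.3-fold lower number from compound 1 to compound 3 (0.10 log units; within the scatter), swaps the whole group and still stays within the scatter, which gives no ground to expect a shift here either. The expectation for compound 4 in this assay is therefore a number close to that of compound 2, with the expected step of a 1.1-fold higher number from compound 2 to compound 4 (0.03 log units; within the scatter) lying within the scatter. Compound 4 is estimated at 5500 nM, with a range from 2000 nM to 15000 nM.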

Compound 4, half-maximal inhibitory concentration: 6100 nM
For compound 4 the middle estimate is 1.1-fold (0.04 log units) below the measured one; the measured number falls inside the stated range.
By their numbers in this assay, from the lowest: compounds 2 and 4 (each within the scatter of the next); then compounds 3 and 1 (each within the scatter of the next).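

Moving the chlorine on the benzyl group is now tested directly: in this assay, the change from 4-chlorobenzyl to 3-chlorobenzyl gives a 1.2-fold higher number from compound 2 to compound 4 (0.08 log units; within the scatter), so at this position, the two chlorophenyl groups cannot be told apart in this measurement. The earlier step at the same place, a 1.3-fold lower number from compound 1 to compound 3 (0.10 log units; within the scatter), was read with hydrogen on the nitrogen on the aromatic ring, whereas this one is read with the (1-bromoethenyl)carbonyl group on that nitrogen, and it too stays within the scatter. Nothing in the data offers a cause for this result.

As far as these compounds go, only the placement of the chlorine is examined within the benzyl group, so a fluorine or a methoxy group in its place, an unsubstituted benzyl, and a longer chain between the ring nitrogen and the aromatic ring all remain open. Also open, from the compounds shown here alone, is whether the large step tied to the (1-bromoethenyl)carbonyl group, a 12-fold higher number from compound 2 to compound 3 (1.07 log units; beyond the scatter), has any counterpart with another group on that nitrogen, such as a plain acetyl.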